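The source may report more compounds than this note shows. Statements on the series, on what has been measured and on what is new or still open speak of the compounds shown alone.

Compound 1 `Nc1sc(-c2ccc(Cl)cc2)c(-c2ccc(Cl)cc2)c1C(=O)N1CCCCC1` gives 14300 nM
Compound 2 `CC(C)CNC(=O)c1c(N)sc(-c2ccc(Cl)cc2)c1-c1ccc(Cl)cc1` gives 13200 nM

In a functional assay on PC-3 cells (Homo sapiens) for inhibition, read by sulforhodamine B assay, with a stated time of 72 h (on this read-out higher numbers stand for weaker inhibition and lower numbers for stronger inhibition), compound 2 gives 13200 nM and sits within the scatter of compound 1. Compound 3 `Nc1sc(-c2ccc(Cl)cc2)c(-c2ccc(Cl)cc2)c1C(=O)N1CCC(=O)CC1=O` changes what hangs on the carbonyl of compound 2: 2,4-dioxopiperidin-1-yl in place of isobutylamino on a carbonyl carbon and, in words, 2,4-dioxopiperidin-1-yl in place of isobutylamino on a carbonyl carbon. Going by the values given here, the only measured exchange at this carbonyl carbon gave a 1.1-fold lower number from compound 1 to compound 2 (0.03 log units; within the scatter) and so no step beyond the scatter is expected in this assay here, though a single step is thin evidence. The expected result is a 1.1-fold higher number from compound 2 to compound 3 (0.03 log units; within the scatter) for now. For compound 3 the estimated value is 14000 nM with 6000 nM to 32000 nM as its likely range.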

Compound 3, half-maximal inhibitory concentration: 9230 nM
Beside the measured number, compound 3's estimate is 1.5-fold (0.18 log units) above it; the measured number falls inside the stated range.
By their numbers in this assay, from the lowest: compounds 3, 2 and 1 (each within the scatter of the next).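

In this assay, the larger 2,4-dioxopiperidin-1-yl group, which has hydrogen-bond acceptors and no hydrogen-bond donor, stays within the scatter of isobutylamino (a 1.4-fold lower number from compound 2 to compound 3 (0.16 log units; within the scatter)) and of piperidin-1-yl (a 1.5-fold lower number from compound 1 to compound 3 (0.19 log units; within the scatter)). So three differently built groups on this carbonyl carbon now give numbers that cannot be told apart, a wider exchange than the first pair covered. Nothing measured here explains this lack of separation.

Still open, on these data alone, is whether a longer chain in place of isobutylamino, or a ring carrying an amine or a carboxylic acid, would move the number beyond the scatter.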